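Compound 3 at the Limit and an Untested Furan Analogue

A few compounds are considered here, and "the series" means these few. Any claim that something is new, unique, unknown or untested is made for them only; others in the source may bear on it.

Measured compounds:
compound 1, `N#C/C(=C\c1ccc(Cl)cc1)C(=O)c1ccc[nH]1`: 48000 nM
compound 2, `N#C/C(=C\c1c[nH]c2ccccc12)C(=O)c1c[nH]c2ccccc12`: 14000 nM
compound 3, `COc1ccc(CNC(=O)/C(C#N)=C/c2ccc[nH]2)cc1`: > 50000 nM

In a functional assay on MIA cells (Homo sapiens) for inhibition, read by MTT assay, with a stated time of 72 h (on this read-out lower numbers stand for stronger inhibition of growth and higher numbers for weaker inhibition of growth), compound 1 gives 48000 nM and compound 2 gives 14000 nM. For compound 3, this assay reports no number but only a limit, > 50000 nM. Compound 3 therefore stands at the limit of > 50000 nM in this assay, at which 1 of the 3 values shown sits, the weakest position the numbers shown can express.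

Compound 4, `COc1ccc(CNC(=O)/C(C#N)=C/c2ccoc2)cc1`, differs from compound 3 in one place: furan-3-yl in place of 1H-pyrrol-2-yl on a double-bonded chain carbon bound to a double-bonded chain carbon. Going by the values given here, no measured pair shows what such an exchange does here. With compound 3 already at the limit, the step that the limit leaves unreadable from compound 3 to compound 4 is expected to stay within the scatter, with no gain in growth inhibition. Compound 4 is accordingly estimated at 60000 nM, within a range of 25000 nM to 150000 nM.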

Compound 4, concentration for 50% growth inhibition: 8000 nM
The estimate for compound 4 lay 7.5-fold (0.88 log units) above the measured number, outside the stated range (below it).
By their numbers in this assay, from the lowest: compounds 4 and 2 (each within the scatter of the next); then compound 1. At a limit, above all of these: compound 3.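

In this assay, furan-3-yl in place of 1H-pyrrol-2-yl on a double-bonded chain carbon bound to a double-bonded chain carbon gives an at least 6.2-fold lower number from compound 3 to compound 4 (0.79 log units; beyond the scatter). Going by these compounds alone, this is the first readable step at this place, and it shows that growth inhibition here responds to the exchange of one five-membered aromatic ring for another. For compound 3 the value is a limit, not a number, so the true size of the step stays open: the limit of > 50000 nM in this assay, at which 1 of the 4 values shown sits.

The compounds shown leave open whether the ring's hetero atom or its point of attachment matters more. A furan-2-yl or 1H-pyrrol-3-yl group at this place would separate the two.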